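The source may report more compounds than this note shows. Statements on the series, on what has been measured and on what is new or still open speak of the compounds shown alone.

Compound 3 `COc1cccc(-n2c(-c3coc4cc(C)c(Cl)cc4c3=O)nc(-c3ccccc3)c2-c2ccccc2)c1` gives 6250 nM in a functional assay on HepG2 cells (Homo sapiens) for inhibition, read by MTT assay, with a stated time of 72 h (on this read-out lower numbers stand for stronger inhibition and higher numbers for weaker inhibition), the lowest of the three numbers, though every neighbour sits within the scatter: compound 1 `COc1ccccc1-n1c(-c2coc3cc(C)c(Cl)cc3c2=O)nc(-c2ccccc2)c1-c1ccccc1` gives 12500 nM and compound 2 `Cc1cc2occ(-c3nc(-c4ccccc4)c(-c4ccccc4)n3-c3ccc(Cl)c(Cl)c3)c(=O)c2cc1Cl` gives 12500 nM. The steps among them are a 2.0-fold lower number from compound 1 to compound 3 (0.30 log units; within the scatter), a 2.0-fold lower number from compound 2 to compound 3 (0.30 log units; within the scatter) and no change at the digits printed from compound 1 to compound 2 (within the scatter), so the aryl group on the ring nitrogen has moved the read-out little so far.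

Compound 4 `Cc1cc2occ(-c3nc(-c4ccccc4)c(-c4ccccc4)n3-c3ccc(Cl)cc3)c(=O)c2cc1Cl` is not yet measured. It differs from compound 3 by 4-chlorophenyl in place of 3-methoxyphenyl on an aromatic nitrogen. Within the data shown here, the one step that bears on it is the swap between a chlorinated phenyl and 3-methoxyphenyl on that nitrogen, a 2.0-fold lower number from compound 2 to compound 3 (0.30 log units; within the scatter), which stayed within the scatter. Compound 4 is therefore expected to give 10000 nM (range 4500 nM to 25000 nM), a step of a 1.6-fold higher number from compound 3 to compound 4 (0.20 log units; within the scatter), because compound 2 showed 12500 nM with the related aryl group.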

Compound 4, half-maximal inhibitory concentration: 1560 nM
The estimate for compound 4 lay 6.4-fold (0.81 log units) above the measured number, and the stated range ends above it.
By their numbers in this assay, from the lowest: compound 4; then compounds 3, 1 and 2 (each within the scatter of the next).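

On the aromatic nitrogen the aryl group does move the read-out in this assay: 4-chlorophenyl gives a 4.0-fold lower number from compound 3 to compound 4 (0.60 log units; beyond the scatter) against 3-methoxyphenyl and an 8.0-fold lower number from compound 1 to compound 4 (0.90 log units; beyond the scatter) against 2-methoxyphenyl. Hydrogen in place of one chloro of the 3,4-dichlorophenyl group gives an 8.0-fold lower number from compound 2 to compound 4 (0.90 log units; beyond the scatter) in this series, so a chlorine on the phenyl does not by itself bring the lower number. Nothing at hand explains these steps.

Open, on these data alone, is whether the lower number holds with 4-bromophenyl, 4-aminophenyl or unsubstituted phenyl on that nitrogen.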